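This account rests on a few compounds, and the source may have more. Where it says the series, first, only, none or still open, it means among the compounds named here.

In an ADME assay on HEK293 cells (Homo sapiens) for cytotoxicity, read by MTT assay, with a stated time of 48 h (a lower number here means a stronger inhibitor, a higher number a weaker inhibitor), compound 1 `O=C1/C(=C\c2cccc(O)c2)S/C(=N/c2ccccc2)N1Cc1ccncc1` gives 150000 nM and compound 2 `O=C1/C(=C\c2cccc(Cl)c2)S/C(=N/c2ccccc2)N1Cc1ccncc1` gives 71800 nM, the lower of the two numbers. Compound 3 `Cc1ccc(/C=C2/S/C(=N/c3ccccc3)N(Cc3ccncc3)C2=O)s1`, not yet measured, differs from compound 2 at a double-bonded chain carbon bound to a double-bonded ring carbon: 5-methylthiophen-2-yl in place of 3-chlorophenyl on a double-bonded chain carbon bound to a double-bonded ring carbon. Among the compounds with values here, the only measured step, a 2.1-fold lower number from compound 1 to compound 2 (0.32 log units; beyond the scatter), is modest and swaps one group on the aromatic ring that compound 3 replaces. Within the data shown here, no measured pair shows a whole-ring exchange, so the direction is uncertain, and no shift beyond the scatter is expected in this assay. The estimated step is a 1.2-fold higher number from compound 2 to compound 3 (0.07 log units; within the scatter). For compound 3 the expected value is 85000 nM, with an estimated range of 35000 nM to 190000 nM.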

Compound 3, half-maximal inhibitory concentration: 146000 nM
The estimate for compound 3 lay 1.7-fold (0.23 log units) below the measured number; the range from low to high includes it.
By their numbers in this assay, from the lowest: compound 2; then compounds 3 and 1 (each within the scatter of the next).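

In this assay, putting 5-methylthiophen-2-yl in place of 3-chlorophenyl at this double-bonded chain carbon gives a 2.0-fold higher number from compound 2 to compound 3 (0.31 log units; beyond the scatter), a modest step beyond the scatter. Putting 5-methylthiophen-2-yl in place of 3-hydroxyphenyl gives a 1.0-fold lower number from compound 1 to compound 3 (0.01 log units; within the scatter), so these two rings cannot be told apart here. As far as these compounds go, whether an amine or a carboxylic acid on this ring, or a longer chain in its place, would shift the number further remains open. No measurement at hand explains these differences.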